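The source may hold more compounds than are shown below. What is called first, only, known or untested is meant among the compounds shown, and "the series" means these compounds.

Compound 1 `COc1ccc(/C=C2\CN(C)C/C(=C\c3cccnc3)C2=O)c(OC)c1OC`: 13600 nM
Compound 2 `CN1C/C(=C\c2ccc(C(F)(F)F)cc2)C(=O)/C(=C/c2cccnc2)C1`: 15600 nM

In an ADME assay on L02 cells (Homo sapiens) for cytotoxicity, read by MTT assay, with a stated time of 24 h (a lower number here means a stronger inhibitor, a higher number a weaker inhibitor), compound 1 gives 13600 nM and compound 2 gives 15600 nM, so the two numbers lie within the usual scatter of each other. Compound 3 `COc1ccc(/C=C2\CN(C)C/C(=C\c3ccncc3)C2=O)c(OC)c1OC` has the same atoms as compound 1, joined differently: pyridin-4-yl in place of pyridin-3-yl on a double-bonded chain carbon bound to a double-bonded ring carbon, with pyridin-4-yl in place of pyridin-3-yl on a double-bonded chain carbon bound to a double-bonded ring carbon. Going by the values given here, no measured pair shows what this change does, and in this assay no step beyond the scatter is expected, in either direction. The estimated 1.0-fold higher number from compound 1 to compound 3 (0.01 log units; within the scatter) is therefore small. Compound 3 is expected at 14000 nM, with an estimated range of 7000 nM to 28000 nM.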

Compound 3, half-maximal inhibitory concentration: 15600 nM
Compound 3: the middle estimate sits 1.1-fold (0.05 log units) below what was measured; low and high end bracket the measured number.
By their numbers in this assay, from the lowest: compounds 1, 2 and 3 (each within the scatter of the next).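

Replacing pyridin-3-yl with pyridin-4-yl on a double-bonded chain carbon bound to a double-bonded ring carbon gives a 1.1-fold higher number from compound 1 to compound 3 (0.06 log units; within the scatter) in this assay and is the first single-place comparison shown. With the rest of the structure held constant, these two pyridine attachments therefore cannot be told apart in this assay. Nothing offered here explains this result. The compounds shown leave open whether pyridin-2-yl or an aminophenyl group at this place would also read alike, and whether the same swap would stay within the scatter in the core of compound 2.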